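The source may hold more compounds than are shown below. What is called first, only, known or untested is meant among the compounds shown, and "the series" means these compounds.

Measured so far in a functional assay on MCF7 cells (Homo sapiens) for antiproliferative activity, with a stated time of 5 days; on this read-out higher numbers stand for weaker inhibition and lower numbers for stronger inhibition:
Compound 1 `CCCCc1ccc2[nH]c(-c3ccc(C(F)(F)F)cc3)c(C=O)c2c1` gives 66 nM in this series.
Compound 2 `CCCCc1ccc2[nH]c(-c3ccc(CC)cc3)c(C=O)c2c1` gives 58 nM in this series.

These two values lie within the scatter of each other, so compound 1 holds no separate rank among the numbers available. Among the measured compounds shown here, the only measured step is a 1.1-fold lower number from compound 1 to compound 2 (0.06 log units; within the scatter) and it comes from ethyl in place of trifluoromethyl on an aromatic carbon.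

Compound 3 `CCCCc1ccc2[nH]c(-c3ccc(C(F)(F)F)cc3)c(/C=N/NC(=O)c3ccncc3)c2c1` differs from compound 1 at another place. The difference is a group of 11 heavy atoms (7 carbon, 3 nitrogen, 1 oxygen; one six-membered aromatic ring with 1 hetero atom) in place of a group of 2 heavy atoms (1 carbon, 1 oxygen; no ring), on an aromatic carbon and it falls where compound 1 carries its formyl. For the measured compounds named here, no measured compound varies this place, so the one measured step gives no guide to the size of this change. The data contain no direct evidence here, and the forecast is therefore loose. With so large a group entering in place of the formyl, a higher number is expected in this assay beyond the scatter, although a value close to that of compound 1 cannot be ruled out. The expected change is a 3.0-fold higher number from compound 1 to compound 3 (0.48 log units; beyond the scatter) on this estimate. For compound 3 the estimated value is 200 nM with an expected range from 30 nM to 1500 nM in this read-out.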

Compound 3, half-maximal inhibitory concentration: 100 nM
The estimate for compound 3 lay 2.0-fold (0.30 log units) above the measured number; measured number inside the range.
By their numbers in this assay, from the lowest: compounds 2, 1 and 3 (each within the scatter of the next).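

In this assay, among the compounds shown here, the place that carries the formyl in compound 1 is now varied for the first time, and a much larger group, with one six-membered aromatic ring with 1 hetero atom, gives a 1.5-fold higher number from compound 1 to compound 3 (0.18 log units; within the scatter). The earlier pair varied only the group that changes from trifluoromethyl to ethyl, so it said nothing about this place; compound 3 now shows that, in this one case, the formyl can be replaced without a change beyond the scatter, despite the large gain in heavy atoms, hydrogen-bond donors and acceptors. No measurement available here bears on why the numbers for these two compounds stay so close.

The compounds shown leave open how smaller groups at this place, such as a carboxylic acid, a primary amine or a nitrile, would compare with the formyl, and whether a plain phenyl ring in place of the ring with its hetero atom would read alike. They also leave open whether the same exchange made on compound 2, which carries ethyl in place of trifluoromethyl, would again stay within the scatter.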